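Ortho chloro for isopropyl on the urea aryl ring

This account rests on a few compounds, and the source may have more. Where it says the series, first, only, none or still open, it means among the compounds named here.

Working notes on a small urea series. Among the compounds with values here, compound 1 `CC(C)c1ccccc1NC(=O)N[C@H](C)c1ccccc1` gives 17% in an ADME assay on the whole organism with Oryza sativa as the target, tested at 10 uM (on this read-out higher numbers stand for a weaker effect at the one concentration tested and lower numbers for a stronger effect), the lowest of the three numbers so far. Within the data shown here, its configurational partner compound 2 `CC(C)c1ccccc1NC(=O)N[C@@H](C)c1ccccc1` gives 93%; the step of a number 76 percentage points higher from compound 1 to compound 2 (beyond the scatter) is the only single-point change measured, and it rests on (the fact that compounds 1 and 2 differ only in the configuration as drawn). Compound 3 `CCCc1ccc(NC(=O)N[C@H](C)c2ccccc2)cc1`, with a propyl at another place on the aryl ring, gives 35%.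

Compound 4 `C[C@@H](NC(=O)Nc1ccccc1Cl)c1ccccc1` keeps the configuration of compound 1 and differs from it by chloro in place of isopropyl on an aromatic carbon. Among the measured compounds shown here, no measured step touches the aryl substituent, so nothing speaks directly to this change; the only related numbers are those of compound 1 and compound 3, which sit some way apart. With the configuration held as in compound 1 and compound 1 being the lowest number seen, the expectation for compound 4 is a moderate move upward, a number 18 percentage points higher from compound 1 to compound 4 (beyond the scatter), with wide uncertainty. Compound 4 is thus estimated at 35%, between 10% and 70%.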

Compound 4, a percentage reported as activity, at one concentration (the size of the read-out at that concentration, not a potency): 93%
Compound 4: middle estimate off by 58 percentage points, on the low side, outside the stated range (above it).
By their numbers in this assay, from the lowest: compound 1; then compound 3; then compounds 2 and 4 (each within the scatter of the next).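

The step of a number 76 percentage points higher from compound 1 to compound 4 (beyond the scatter) shows that in this assay this aromatic carbon, ortho to a large group, is far from indifferent: with the configuration of compound 1 held, chloro in place of isopropyl gives up the low number of compound 1. Within the data shown here, until now the only single-point change measured was the configurational one, a number 76 percentage points higher from compound 1 to compound 2 (beyond the scatter), so the low number of compound 1 now depends on the isopropyl as well as on the configuration as drawn. Nothing at hand gives a cause for the step from isopropyl to chloro.

As far as these compounds go, what stays open is whether the number follows the count of heavy atoms at this place or something particular to isopropyl, a question that a methyl, an ethyl or a tert-butyl group there would address. A methoxy group at the same carbon would show whether a group other than an alkyl can hold a low number.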